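Cyclopentyl Amide Exchange on Two Related Cores

The source may hold more compounds than are shown below. What is called first, only, known or untested is meant among the compounds shown, and "the series" means these compounds.

Compound 1 `CC[C@@H]1C(=O)N(C)c2cnc(-n3ccc4cc(C(=O)NCC(C)C)ccc43)nc2N1C1CCCC1` and compound 3 `CC[C@@H]1C(=O)N(C)c2cnc(-n3ccc4cc(C(=O)NC5CCCC5)ccc43)nc2N1C1CCCC1` share one core, while compound 2 `CCC1C(=O)N(C)c2cnc(-n3ccc4cc(C(=O)NCC(C)C)ccc43)nc2N1c1ccn(C)n1` carries a different group on the core; the difference between the two cores is not broken down here. In a functional assay on A549 cells (Homo sapiens) for antiproliferative activity, read by CCK-8 assay, with a stated time of 72 h (on this read-out higher numbers stand for weaker inhibition of growth and lower numbers for stronger inhibition of growth), compound 1 gives 1730 nM, compound 3 gives 670 nM, and compound 2 gives 19200 nM, the highest of the three numbers. The change from compound 1 to compound 3 is cyclopentyl in place of isobutyl on an amide-type nitrogen, and it produced a 2.6-fold lower number from compound 1 to compound 3 (0.41 log units; beyond the scatter).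

Compound 4 `CCC1C(=O)N(C)c2cnc(-n3ccc4cc(C(=O)NC5CCCC5)ccc43)nc2N1c1ccn(C)n1` has not yet been measured. It stands to compound 2 as compound 3 stands to compound 1: cyclopentyl in place of isobutyl on an amide-type nitrogen, the same change at the same place. Because the same exchange on the other core gave a 2.6-fold lower number from compound 1 to compound 3 (0.41 log units; beyond the scatter), he expects a step of similar size from compound 2, namely a 2.6-fold lower number from compound 2 to compound 4 (0.41 log units; beyond the scatter), though a single precedent leaves room for the two cores to answer differently. On that basis, the number expected for compound 4 in this assay is 7500 nM, with a plausible range from 3000 nM to 20000 nM.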

Compound 4, concentration for 50% growth inhibition: 39500 nM
Compound 4: the middle estimate sits 5.3-fold (0.72 log units) below what was measured; measured number outside the range, above it.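

In this assay, cyclopentyl in place of isobutyl on an amide-type nitrogen gave a 2.1-fold higher number from compound 2 to compound 4 (0.31 log units; beyond the scatter), so on the core of compound 2 the exchange did not lower the number as it had on the core of compound 1. The two outcomes run in opposite directions, and the gap between them is real: the same change on two cores in this assay, a 2.6-fold lower number (0.41 log units; beyond the scatter) from compound 1 to compound 3 and a 2.1-fold higher number (0.31 log units; beyond the scatter) from compound 2 to compound 4, 5.3-fold (0.73 log units) apart, beyond the scatter of two such steps. This shows that, in this series, the step measured on one core could not be carried over to the other, but with a single pair on each core it does not show what sets the direction of the step or how the exchange would behave on any further core.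

The compounds shown leave open which part of the difference between the two cores decides the outcome. Also open, from the compounds shown here alone, is how a cyclobutyl, a cyclohexyl or a chain ending in an amine on the same amide-type nitrogen would read on either core.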